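The source may report more compounds than this note shows. Statements on the series, on what has been measured and on what is new or still open speak of the compounds shown alone.

Working notes on the series, all read in a functional assay on a cell-free system (Platelet, plasma, Homo sapiens) for inhibition; on this read-out lower numbers stand for stronger inhibition and higher numbers for weaker inhibition. Among the measured compounds shown here, compound 1 `Cc1ccc(N(CCN2CCC(OCC(=O)O)CC2)C(=O)c2cccc(F)c2)cc1` gives 160 nM, the lowest number so far. Compound 2 `O=C(O)COC1CCN(CCN(C(=O)c2cccc(F)c2)c2ccc(Cl)cc2)CC1` gives 340 nM. Compound 3 `O=C(O)COC1CCN(CCN(C(=O)c2cccc(C(F)(F)F)c2)c2ccc(Cl)cc2)CC1` gives > 10000 nM, which is a limit of the assay and not a number.

The next compound to be read is compound 4 `COc1cccc(C(=O)N(CCN2CCC(OCC(=O)O)CC2)c2ccc(C)cc2)c1OC`. Its difference from the core of compound 1 is 2,3-dimethoxyphenyl in place of 3-fluorophenyl on a carbonyl carbon.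

The modest step of a 2.1-fold higher number from compound 1 to compound 2 (0.33 log units; beyond the scatter) swaps chloro for methyl on the other aromatic group, so it bears only weakly on this change. The step of an at least 29-fold higher number from compound 2 to compound 3 (1.46 log units; beyond the scatter) swaps trifluoromethyl for fluoro on the aromatic group that compound 4 also alters. It is large, so a clear move toward weaker inhibition is expected in this assay, though one step fixes its size poorly.

The expected change is a 7.5-fold higher number from compound 1 to compound 4 (0.88 log units; beyond the scatter). For compound 4 the estimate is 1200 nM, with an expected range from 180 nM to 8000 nM.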

Compound 4, half-maximal inhibitory concentration: 1600 nM
Compound 4: the middle estimate sits 1.3-fold (0.12 log units) below what was measured, within the range that was stated.
By their numbers in this assay, from the lowest: compound 1; then compound 2; then compound 4. At a limit, above all of these: compound 3.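

In this assay, the step to the 2,3-dimethoxyphenyl group on the carbonyl carbon is a 10-fold higher number from compound 1 to compound 4 (1.00 log units; beyond the scatter), which shows that a change at this position can move the number upward while still giving a measured value. The entering group has more heavy atoms than 3-fluorophenyl and carries hydrogen-bond acceptors where 3-fluorophenyl has none, but this single step cannot separate those differences or assign the rise to either one. Compound 3, altered on the same aromatic group, remains a limit of the assay and not a number: the limit of > 10000 nM in this assay, at which 1 of the 4 values shown sits.

Open is which of the two methoxy groups accounts for the step, since the series shown holds no compound with only one of them. Also open, as far as these compounds go, is how this position reads with a nitrile or an amine on the aromatic group.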